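A few compounds are considered here, and "the series" means these few. Any claim that something is new, unique, unknown or untested is made for them only; others in the source may bear on it.

Three compounds share one core and differ only in the group attached through an oxygen to an aromatic ring. Compound 1 `Cn1c(COc2cccc(C(=O)O)c2)nc2cnc(Oc3ccc4c(c3)CCC4)cc21` gives 70 ug/mL in a physicochemical assay for solubility, read by HPLC, measured as thermodynamic solubility, with a stated time of 4 h, at pH 6.8; on this read-out higher numbers stand for higher solubility and lower numbers for lower solubility. Compound 2 `Cn1c(COc2cccc(C(=O)O)c2)nc2ccc(Oc3cccc(Cl)n3)cc21` gives 7.7 ug/mL, and compound 3 `Cn1c(COc2cccc(C(=O)O)c2)nc2ccc(Oc3cc(Cl)ccn3)cc21` gives 11 ug/mL, so compound 3 sits well below compound 1 and close to compound 2. For the measured compounds named here, the only measured step, a 1.4-fold higher number from compound 2 to compound 3 (0.15 log units; within the scatter), moves a chloro to another place on the same pyridyl ring and stays within the scatter. Compound 4 `Cc1ccnc(Oc2ccc3nc(COc4cccc(C(=O)O)c4)n(C)c3c2)c1` differs from compound 3 by methyl in place of chloro on an aromatic carbon. Going by the values given here, no measured step swaps chloro for methyl, so nothing bears on it directly. With the neighbouring step so small, little movement is expected, roughly a 1.1-fold higher number from compound 3 to compound 4 (0.04 log units; within the scatter). Compound 4 is therefore estimated at 12 ug/mL, between 4 ug/mL and 35 ug/mL.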

Compound 4, solubility: 33 ug/mL
Estimate against measurement, compound 4: 2.8-fold (0.44 log units) below; the measured number falls inside the stated range.
By their numbers in this assay, from the lowest: compounds 2 and 3 (each within the scatter of the next); then compound 4; then compound 1.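

In this assay, the pyridyl ring now shows a change beyond the scatter: with methyl in place of chloro, there is a 3.0-fold higher number from compound 3 to compound 4 (0.48 log units; beyond the scatter) at this position opposite the ring nitrogen. Replacing 6-chloropyridin-2-yl with 4-methylpyridin-2-yl gives a 4.3-fold higher number from compound 2 to compound 4 (0.63 log units; beyond the scatter) as well, whereas moving the chloro alone stayed within the scatter. No measurement here explains the rise. From the compounds shown here alone, whether methoxy or an amine at this position would give a higher or lower number remains open, as does whether 6-methylpyridin-2-yl would behave like 4-methylpyridin-2-yl.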